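Shifting a Methoxy Group: Compound 2 to Compound 4

The compounds below may be only part of what the source reports. "The series", "measured", "known", "first", "only" and "open" are said of these compounds alone.

Of the compounds shown here, three sharing one core have been measured in a functional assay on HT-29 cells (Homo sapiens) for antiproliferative activity, read by sulforhodamine B assay, with a stated time of 48 h; a higher number here means a weaker inhibitor of growth, a lower number a stronger inhibitor of growth. Compound 1 `CC(C)(C)c1ccc(-c2cc(N3CCC(CNS(N)(=O)=O)CC3)ncn2)cc1` gives 8900 nM and compound 3 `CCOC(=O)c1ccc(-c2cc(N3CCC(CNS(N)(=O)=O)CC3)ncn2)cc1` gives 5700 nM; the step of a 1.6-fold lower number from compound 1 to compound 3 (0.19 log units; within the scatter) separates them. Compound 2 `COc1ccc(-c2cc(N3CCC(CNS(N)(=O)=O)CC3)ncn2)cc1` reaches only the limit of this assay, > 100000 nM, and no number is known for it. Compound 2 thus stands at the weak end of the three, as the limit of > 100000 nM in this assay, at which 1 of the 3 values shown sits, shows, and the steps of an at least 11-fold higher number from compound 1 to compound 2 (1.05 log units; beyond the scatter) and an at least 17-fold lower number from compound 2 to compound 3 (1.24 log units; beyond the scatter) both run far beyond the scatter.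

Compound 4 `COc1ccccc1-c1cc(N2CCC(CNS(N)(=O)=O)CC2)ncn1` differs from compound 2 by 2-methoxyphenyl in place of 4-methoxyphenyl on an aromatic carbon; the two have the same atoms, joined differently. Within the data shown here, none of the measured steps moves the methoxy group itself; each exchanges it for another group, so they set no direct precedent for the change from compound 2 to compound 4. What they do show is that compound 2 is the only one of the three to sit at the limit, so any value for compound 4 that appears as a number would count as a gain. Among the measured compounds shown here, with no precedent to draw on, the expected step of a number no higher from compound 2 to compound 4 (the limit leaves the size open) is taken as small. Compound 4 is estimated at 100000 nM, within a range from 30000 nM to 300000 nM, and is expected to lie close to the limit itself.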

Compound 4, concentration for 50% growth inhibition: > 100000 nM
Compound 4 was reported as a limit; the forecaster's own chance of this, stated with the estimate: 60%; the middle value sits exactly at the limit.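

Compound 4, like compound 2, is reported only as a limit in this assay, so no step between compound 2 and compound 4 can be read: the limit of > 100000 nM in this assay, at which 2 of the 4 values shown sit.

The compounds shown leave open whether 2-methoxyphenyl in place of 4-methoxyphenyl changes growth inhibition at all, and in which direction, since neither compound has a number.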